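This account rests on a few compounds, and the source may have more. Where it says the series, first, only, none or still open, it means among the compounds named here.

Working notes on the series. The shared core carries a side chain that varies at one position. Compound 1 is `CSCC[C@H](NC(=O)CN(c1nc(Cl)nc2[nH]cnc12)C1CC1)C(=O)OCc1ccccc1`; in a functional assay on the whole organism (Tail, strain ICR) with Mus musculus as the target, in the tail flick test, with a stated time of 60 min, at a dose of 25 umol/kg by the oral route (a higher number here means a stronger effect of the compound at the dose given, a lower number a weaker effect), compound 1 gives 30.8%. Compound 2 is `NC(=O)CC[C@H](NC(=O)CN(c1nc(Cl)nc2[nH]cnc12)C1CC1)C(=O)OCc1ccccc1`; in this assay compound 2 gives 33.1%. Going by the values given here, the only measured step, a number 2.3 percentage points higher from compound 1 to compound 2 (within the scatter), is within the scatter, so compound 2 and compound 1 cannot be told apart on these numbers, and compound 2 stands simply as one of two values of the same size.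

Compound 3 is `C[C@@H](O)[C@H](NC(=O)CN(c1nc(Cl)nc2[nH]cnc12)C1CC1)C(=O)OCc1ccccc1`. It differs from compound 2 by 1-hydroxyethyl in place of 2-carbamoylethyl on a saturated chain carbon bound to an amide-type nitrogen and a carbonyl carbon. The step from compound 1 to compound 2 is the only one available and it exchanged a side-chain terminus without a change beyond the scatter; it is a different exchange from the one here, which replaces the whole 2-carbamoylethyl group by 1-hydroxyethyl, so it bears on it only loosely. Nothing in the data points to a step beyond the scatter in either direction. Compound 3 is therefore expected to stay close to compound 2, with an estimated step of a number 1.1 percentage points lower from compound 2 to compound 3 (within the scatter). The estimate for compound 3 is 32%, within 20% to 44%.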

Compound 3, a percentage reported as activity, at one dose (the size of the read-out at that dose, not a potency): 29.7%
Compound 3: middle estimate off by 2.3 percentage points, on the high side; the range from low to high includes it.
By their numbers in this assay, from the lowest: compounds 3, 1 and 2 (each within the scatter of the next).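

In this assay the earlier step exchanged only a side-chain terminus, whereas here the whole group on the saturated chain carbon bound to an amide-type nitrogen and a carbonyl carbon is replaced: 2-carbamoylethyl with 5 heavy atoms gives way to 1-hydroxyethyl with 3 heavy atoms and 1 defined stereocentre, and the result is a number 3.4 percentage points lower from compound 2 to compound 3 (within the scatter) with no separation from the other side chain either, the second step being a number 1.1 percentage points lower from compound 1 to compound 3 (within the scatter) as well. Compounds 1, 2 and 3 therefore cannot be told apart at this dose, so neither the exchange of the whole group nor the smaller heavy-atom count of the group that enters shows any effect beyond the scatter in this series. No other measurement accompanies these numbers, so the result cannot be traced to any property of these groups.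

Going by these compounds, whether any group at this position can move the read-out beyond the scatter remains open, for example a primary amine, a carboxylic acid or a longer alkyl chain. Also open, on these data alone, is whether 1-hydroxyethyl with the opposite configuration at its stereocentre would stay level with compound 3 in this assay, and whether these compounds differ at other doses.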